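Phenyl for 1H-pyrazol-4-yl on a compound at the assay limit

This account rests on a few compounds, and the source may have more. Where it says the series, first, only, none or still open, it means among the compounds named here.

Compound 1 (`CC(c1cc(F)c2ncccc2c1)n1cnc2ncc(-c3cn[nH]c3)nc21`) is the only reference point in this small series. In a functional assay on NCI-H1993 cells (Homo sapiens) for inhibition, read by CCK-8 assay, with a stated time of 72 h (a lower number here means a stronger inhibitor, a higher number a weaker inhibitor), compound 1 gives > 10000 nM as its reading, which is a limit of the assay and not a number. Compound 2 (`CCC(c1cc2cccnc2cc1F)n1cnc2ncc(-c3cnn(CCO)c3)nc21`) gives "not determined" (no result reported) in this assay and so offers no comparison. Within the data shown here, the measured picture therefore comes down to the limit of > 10000 nM in this assay, at which 1 of the 2 values shown sits, and nothing more, with no step between two measured compounds to draw on.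

Compound 3 (`CC(c1cc(F)c2ncccc2c1)n1cnc2ncc(-c3ccccc3)nc21`) differs from compound 1 by phenyl in place of 1H-pyrazol-4-yl on an aromatic carbon with phenyl in place of 1H-pyrazol-4-yl on an aromatic carbon of the six-membered aromatic ring with 2 nitrogen.

The expectation rests on compound 1 alone, whose reading of > 10000 nM is a limit and gives no number to start from. The expected change, a number no higher from compound 1 to compound 3 (the limit leaves the size open) as estimated here, is no step beyond the scatter in either direction in this assay for now. For compound 3 the expected half-maximal inhibitory concentration is 10000 nM within an estimated range of 3000 nM to 30000 nM at the weak end of the assay, and a reading reported only as a limit is quite likely.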

Compound 3, half-maximal inhibitory concentration: > 10000 nM
Compound 3: a limit, no number; the forecaster's own chance of this, stated with the estimate: 65%; the middle value lies on the limit itself.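

In this assay compound 3 gives > 10000 nM, a limit of the assay and not a number. No step from compound 1 to compound 3 can be read, as both readings are limits: the limit of > 10000 nM in this assay, at which 2 of the 3 values shown sit.

The compounds shown leave open whether any group at this place on the shared core gives a single number in this assay.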